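The source may hold more compounds than are shown below. What is called first, only, known or untested is meant among the compounds shown, and "the series" means these compounds.

In a functional assay on HepG2 cells (Homo sapiens) for inhibition, read by MTT assay, with a stated time of 48 h (on this read-out lower numbers stand for stronger inhibition and higher numbers for weaker inhibition), compound 3 (`COc1ccc(CSc2nnc(-c3cc(OC)c(OC)c(OC)c3)n2-c2ccc(N(C)C)cc2)cc1`) gives only a limit, > 60000 nM. This places compound 3 at the limit of > 60000 nM in this assay, at which 2 of the 3 values shown sit. Compound 2 (`COc1cc(-c2nnc(SC)n2-c2ccc(N(C)C)cc2)cc(OC)c1OC`) is also a limit, > 60000 nM. Compound 4 (`COc1cc(-c2nnc(SCc3ccc(F)cc3)n2-c2ccc(N(C)C)cc2)cc(OC)c1OC`) changes compound 3 by fluoro in place of methoxy on an aromatic carbon. For the measured compounds named here, the one measured step here, a step that the two limits leave unreadable from compound 2 to compound 3, offers no size to carry over. Compound 1 (`COc1ccc(-n2c(SCc3ccc(F)cc3)nnc2-c2cc(OC)c(OC)c(OC)c2)cc1`) also has the (4-fluorobenzyl)sulfanyl group and gives 35000 nM, though it differs from compound 4 elsewhere. That number gives only a loose guide, so a modest step with no firm direction is expected. The step estimated in this assay is an at least 1.0-fold lower number from compound 3 to compound 4 (0.03 log units; that floor lies within the scatter). For compound 4 the estimated value is 55000 nM, with an expected range from 25000 nM to 120000 nM.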

Compound 4, half-maximal inhibitory concentration: 26400 nM
Compound 4: middle estimate off by 2.1-fold (0.32 log units), on the high side; low and high end bracket the measured number.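

In this assay, fluoro in place of methoxy on an aromatic carbon brings a readable number to the dimethylamino compounds, with an at least 2.2-fold lower number from compound 3 to compound 4 (0.35 log units; beyond the scatter), and the 4-fluorobenzyl group does likewise against the small methyl-bearing compound, with an at least 2.2-fold lower number from compound 2 to compound 4 (0.35 log units; beyond the scatter). With the (4-fluorobenzyl)sulfanyl group kept, dimethylamino and methoxy cannot be told apart, with a 1.3-fold lower number from compound 1 to compound 4 (0.12 log units; within the scatter). Compound 2 and compound 3 are only limits, so the step between them cannot be read: the limit of > 60000 nM in this assay, at which 2 of the 4 values shown sit.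

As far as these compounds go, whether this lower number is specific to fluoro stays open. A chloro or trifluoromethyl group on that same aromatic carbon would help to settle it.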